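The source may report more compounds than this note shows. Statements on the series, on what has been measured and on what is new or still open speak of the compounds shown alone.

Within the data shown here, compound 3 `CCCCCC(=O)Nc1ccc(S(=O)(=O)Oc2ccccc2I)cc1` gives 11000 nM in a functional assay on M21 cells (Homo sapiens) for antiproliferative activity, read by sulforhodamine B assay, with a stated time of 48 h (on this read-out lower numbers stand for stronger inhibition and higher numbers for weaker inhibition), the second highest of the three numbers measured so far. Its nearest neighbour is compound 2 `CCCCCC(=O)Nc1ccc(S(=O)(=O)Oc2ccccc2C(C)C)cc1`, which in this assay gives 6700 nM; the step of a 1.6-fold higher number from compound 2 to compound 3 (0.22 log units; within the scatter) lies within the scatter. The furthest is compound 1 `CCC(=O)Nc1cccc(S(=O)(=O)Oc2ccccc2C(C)C)c1`, which in this assay gives 25000 nM, a step beyond the scatter from compound 3.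

Compound 4 `CCNC(=O)Nc1ccc(S(=O)(=O)Oc2ccccc2I)cc1` has not yet been measured. It differs from compound 3 by ethylamino in place of pentyl on a carbonyl carbon. Among the measured compounds shown here, no measured step touches that place: the only single-point step, a 1.6-fold higher number from compound 2 to compound 3 (0.22 log units; within the scatter), concerns the exchange of iodo for isopropyl and is within the scatter. For the measured compounds named here, compound 1 and compound 2 differ in two places at once, so their values show only that the compound with the shorter chain on the carbonyl carbon carries the higher number. Going by the values given here, there is thus no measured step that bears directly on the change to compound 4, and the expectation rests on the shorter group entering and on compound 1 showing 25000 nM. The step of a 1.8-fold higher number from compound 3 to compound 4 (0.26 log units; within the scatter) is expected to be a modest rise in the number, near the edge of the scatter. Compound 4 is therefore estimated at 20000 nM, with a range from 6000 nM to 60000 nM.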

Compound 4, half-maximal inhibitory concentration: 5600 nM
Estimate against measurement, compound 4: 3.6-fold (0.55 log units) above, outside the stated range (below it).
By their numbers in this assay, from the lowest: compounds 4, 2 and 3 (each within the scatter of the next); then compound 1.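

In this assay, among these compounds, the exchange of pentyl for ethylamino on the carbonyl carbon gives the first measured single-place step at this position, a 2.0-fold lower number from compound 3 to compound 4 (0.29 log units; within the scatter), which lies within the scatter. The (pentylcarbonyl)amino group can therefore give way to the (ethylcarbamoyl)amino group, which adds a nitrogen and a hydrogen-bond donor and has fewer heavy atoms, without the number leaving the scatter on this iodo-bearing core. The change alters the chain and the atom attached to the carbonyl carbon together, so this single step cannot separate the two, and nothing available here accounts for the result.

The compounds shown leave open whether a pentylamino group on the carbonyl carbon, which would keep the five-carbon chain while adding the nitrogen, would also stay within the scatter of compound 3. They also leave open whether a carboxylic acid or a cyclic amine carried on that chain would move the number beyond the scatter, and whether the ethylamino group would behave in the same way with isopropyl in place of iodo.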